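Swapping a Cyclohexyl Amide for a Hydroxypiperidine Amide

A few compounds are considered here, and "the series" means these few. Any claim that something is new, unique, unknown or untested is made for them only; others in the source may bear on it.

The measured compounds and their values:
compound 1 `COc1ncc(-c2ccc3ncc(NC(=O)C4CCCCC4)c(OC)c3c2)cc1NS(=O)(=O)c1ccc(F)cc1F`, 4610 nM
compound 2 `COc1ncc(-c2ccc3ncc(NC(=O)CN4CCN(C)CC4)c(OC)c3c2)cc1NS(=O)(=O)c1ccc(F)cc1F`, 1540 nM
compound 3 `COc1ncc(-c2ccc3ncc(NCC4CCN(S(C)(=O)=O)CC4)c(OC)c3c2)cc1NS(=O)(=O)c1ccc(F)cc1F`, 1360 nM

All three share one core and were tested in a functional assay on HCT-116 cells (Homo sapiens) for antiproliferative activity, read by sulforhodamine B assay, with a stated time of 72 h; a higher number here means a weaker inhibitor, a lower number a stronger inhibitor. Compound 1 gives the highest number of the three, so it is the weakest inhibitor here: the step of a 3.0-fold lower number from compound 1 to compound 2 (0.48 log units; beyond the scatter) and the step of a 3.4-fold lower number from compound 1 to compound 3 (0.53 log units; beyond the scatter) both lie beyond the scatter, while compound 2 and compound 3 differ only by a 1.1-fold lower number from compound 2 to compound 3 (0.05 log units; within the scatter), which is within the scatter.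

Compound 4 `COc1ncc(-c2ccc3ncc(NC(=O)CN4CCCC(O)C4)c(OC)c3c2)cc1NS(=O)(=O)c1ccc(F)cc1F` is not yet measured. It differs from compound 1 in one place: (3-hydroxypiperidin-1-yl)methyl in place of cyclohexyl on a carbonyl carbon. Among the measured compounds shown here, the closest precedent is the step from compound 1 to compound 2, where a ring-bearing methyl group carrying a nitrogen likewise replaced the cyclohexyl on the same carbonyl carbon, and the number fell by a 3.0-fold lower number from compound 1 to compound 2 (0.48 log units; beyond the scatter). The step to compound 3 points the same way. A modest drop in this assay is therefore expected for compound 4, of about a 3.1-fold lower number from compound 1 to compound 4 (0.49 log units; beyond the scatter).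

Compound 4 is estimated to give 1500 nM in this assay, within a range of 600 nM to 4000 nM.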

Compound 4, half-maximal inhibitory concentration: 1770 nM
For compound 4 the middle estimate is 1.2-fold (0.07 log units) below the measured one, within the range that was stated.
By their numbers in this assay, from the lowest: compounds 3, 2 and 4 (each within the scatter of the next); then compound 1.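

In this assay, the (3-hydroxypiperidin-1-yl)methyl group on the carbonyl carbon also gives a lower number than cyclohexyl (a 2.6-fold lower number from compound 1 to compound 4 (0.42 log units; beyond the scatter)), so compound 1 now stands apart from three replacements rather than two. The new information lies at the far end of the group: 3-hydroxypiperidin-1-yl in place of 4-methylpiperazin-1-yl leaves the number within the scatter (a 1.1-fold higher number from compound 2 to compound 4 (0.06 log units; within the scatter)), so the methyl-bearing ring nitrogen of compound 2 is not required for the lower number seen against cyclohexyl. Compound 4 also cannot be told apart from compound 3, which carries a different group on the aromatic nitrogen (a 1.3-fold higher number from compound 3 to compound 4 (0.11 log units; within the scatter)), and so the three replacements form one level in this assay.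

Nothing given here explains why these different groups land at one level. A plain piperidin-1-yl on the same saturated chain carbon would show whether the hydroxyl counts at all, and a morpholine or a carboxylic acid there would test how far this level holds.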